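The source may report more compounds than this note shows. Statements on the series, on what has been measured and on what is new or still open speak of the compounds shown alone.

Working notes on the series. The shared core is seen in compound 1, `C=C(Cl)c1cn([C@H]2C[C@H](O)[C@@H](CO)O2)c(=O)[nH]c1=O`, which in an ADME assay on L1210/0 cells (Mus musculus) for cytotoxicity, with a stated time of 48 h (a lower number here means a stronger inhibitor, a higher number a weaker inhibitor), gives 1660 nM. Compound 2, `CC#Cc1cn([C@H]2C[C@H](O)[C@@H](CO)O2)c(=O)[nH]c1=O`, is reported in this assay only as a limit, > 200000 nM, not as a number. Compound 2 therefore stands at the limit of > 200000 nM in this assay, at which 1 of the 2 values shown sits. For the measured compounds named here, the single measured step, an at least 120-fold higher number from compound 1 to compound 2 (2.08 log units; beyond the scatter), replaces the whole substituent on the aromatic carbon and so does not cover the change now at hand. Compound 3, `CC(C)(C)C#Cc1cn([C@H]2C[C@H](O)[C@@H](CO)O2)c(=O)[nH]c1=O`, carries tert-butyl in place of methyl on a triple-bonded carbon. Going by the values given here, no measured step alters a group on a triple-bonded carbon, so no direction can be read from the data for this change. With compound 2 already at a limit, compound 3 is expected to remain in the same region, an expected step of a number no higher from compound 2 to compound 3 (the limit leaves the size open) in this assay, and to return a limit again rather than a number. The estimate for compound 3 in this assay is 200000 nM, with a range from 50000 nM to 1000000 nM.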

Compound 3, half-maximal inhibitory concentration: > 200000 nM
Compound 3: a limit, no number; the forecaster's own chance of this, stated with the estimate: 75%; the middle value sits exactly at the limit.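

With tert-butyl in place of methyl on the triple-bonded carbon, this assay still returns no number, so a number is not recovered at this position by going from prop-1-yn-1-yl to 3,3-dimethylbut-1-yn-1-yl. The step between compound 2 and compound 3 cannot be read, as both are limits. Against the 1-chloroethenyl group on the aromatic carbon, the second group on a triple-bonded carbon also gives an at least 120-fold higher number from compound 1 to compound 3 (2.08 log units; beyond the scatter), so the large step is no longer tied to prop-1-yn-1-yl alone: the limit of > 200000 nM in this assay, at which 2 of the 3 values shown sit.

From the compounds shown here alone, how far compound 2 and compound 3 lie past the limit remains unknown, and the effect of methyl against tert-butyl with it. Going by these compounds, whether a hydrogen, a hydroxymethyl group or an amine on the triple-bonded carbon would return a number stays open.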